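The source may report more compounds than this note shows. Statements on the series, on what has been measured and on what is new or still open speak of the compounds shown alone.

Compound 3 `CC1=C(C(=O)OCC2CCC2)C(c2ccco2)NC(=O)N1` gives 1% in an assay on membranes from HeLa cells for displacement of a labelled ligand from adenosine receptor A3 (Homo sapiens), read by scintillation counting, with a stated time of 180 min, tested at 1 uM (a higher number here means more inhibition at the concentration tested (going by the name of the read-out), a lower number less inhibition), the lowest of the three numbers in hand; compound 1 `CC1=C(C(=O)C2CC2)C(c2ccoc2)NC(=O)N1` gives 16% and compound 2 `CCN(CC)C(=O)C1=C(C)NC(=O)NC1c1ccoc1` gives 37%. Going by the values given here, the only measured step, a number 21 percentage points higher from compound 1 to compound 2 (beyond the scatter), concerns the group on the carbonyl carbon and does not touch the furan. Compound 4 `CC1=C(C(=O)OCC2CCC2)C(c2ccoc2)NC(=O)N1` differs from compound 3 by furan-3-yl in place of furan-2-yl on a saturated ring carbon. Among the compounds with values here, no measured pair isolates this change, so there is no step to scale an expectation from; compounds 1 and 2 show only that the furan-3-yl pattern can reach a modest number when other parts differ. Compound 4 is therefore expected to move by a number 7 percentage points higher from compound 3 to compound 4 (within the scatter), which may lie within the scatter. Compound 4 is estimated at 8%, between 0% and 25%.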

Compound 4, a percentage reported as inhibition, at one concentration (the size of the read-out at that concentration, not a potency): 2%
Compound 4: middle estimate off by 6 percentage points, on the high side, within the range that was stated.
By their numbers in this assay, from the lowest: compounds 3 and 4 (each within the scatter of the next); then compound 1; then compound 2.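

In this assay, going by these compounds alone, furan-3-yl in place of furan-2-yl on the saturated ring carbon is the first direct test of this change, and with cyclobutylmethoxy on the carbonyl carbon it gives (a number 1 percentage points higher from compound 3 to compound 4 (within the scatter)), so the two furans are not separated here. With furan-3-yl held constant, the carbonyl group does matter, with (a number 35 percentage points lower from compound 2 to compound 4 (beyond the scatter)) and (a number 14 percentage points lower from compound 1 to compound 4 (beyond the scatter)). Nothing available explains these numbers. Going by these compounds, whether the furan change stays this small with diethylamino or cyclopropyl on the carbonyl carbon remains open. So does the result of a phenyl or thiophene group on the saturated ring carbon.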